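Hydroxy for trifluoromethoxy on a terphenyl benzimidazole series

This account rests on a few compounds, and the source may have more. Where it says the series, first, only, none or still open, it means among the compounds named here.

Three compounds sharing a terphenyl chain capped by a benzimidazole have been tested in a functional assay on Gurav cells (Homo sapiens) for inhibition, read by sulforhodamine B assay; on this read-out lower numbers stand for stronger inhibition of growth and higher numbers for weaker inhibition of growth. Compound 1 `Oc1cccc2[nH]c(-c3ccc(-c4ccc(-c5ccc(OC(F)(F)F)cc5)cc4)cc3)nc12` gives 3600 nM. Compound 2 `Oc1ccc(-c2ccc(-c3ccc(-c4nc5c(O)cccc5[nH]4)cc3)cc2)cc1` gives 190 nM, and compound 3 `Cc1ccc2[nH]c(-c3ccc(-c4ccc(-c5ccc(OC(F)(F)F)cc5)cc4)cc3)nc2c1` gives 11000 nM, the highest number of the three.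

The change from compound 1 to compound 2 is hydrogen in place of trifluoromethyl on an oxygen on an aromatic ring. It made a large step: a 19-fold lower number from compound 1 to compound 2 (1.28 log units; beyond the scatter). The change from compound 1 to compound 3 is 5-methyl-1H-benzimidazol-2-yl in place of 4-hydroxy-1H-benzimidazol-2-yl on an aromatic carbon; it made a modest step in the other direction: a 3.1-fold higher number from compound 1 to compound 3 (0.49 log units; beyond the scatter).

Compound 4 `Cc1ccc2[nH]c(-c3ccc(-c4ccc(-c5ccc(O)cc5)cc4)cc3)nc2c1` has not yet been measured. It differs from compound 3 by hydrogen in place of trifluoromethyl on an oxygen on an aromatic ring, which is the same change as that between compound 1 and compound 2, made on the same place. The two cores differ as described by the difference between compound 1 and compound 3. Because the earlier step of a 19-fold lower number from compound 1 to compound 2 (1.28 log units; beyond the scatter) was large and was made on the same place, the same kind of step is expected in this assay from compound 3 to compound 4, roughly a 16-fold lower number from compound 3 to compound 4 (1.20 log units; beyond the scatter), although the differing core leaves room for the size to vary. Compound 4 is therefore expected to give about 700 nM in this assay, with a plausible range from 200 nM to 3000 nM.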

Compound 4, concentration for 50% growth inhibition: 11300 nM
Compound 4: middle estimate off by 16-fold (1.21 log units), on the low side, and the stated range ends below it.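

In this assay, the change from trifluoromethoxy to hydroxy gave a 1.0-fold higher number from compound 3 to compound 4 (0.01 log units; within the scatter), so the large gain seen on the core of compound 1 did not carry over to the core of compound 3, and the two results differ clearly: the same change on two cores in this assay, a 19-fold lower number (1.28 log units; beyond the scatter) from compound 1 to compound 2 and a 1.0-fold higher number (0.01 log units; within the scatter) from compound 3 to compound 4, 19-fold (1.29 log units) apart, beyond the scatter of two such steps

This shows that, for these two cores, the size of the step cannot be taken from one core and applied to the other, even though the change is made on the same place in both. It does not show which feature of the cores is responsible or why the step vanishes on one of them, and two pairs of compounds give no rule for how the change would behave on any other core in the series.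

The compounds shown leave open whether a core carrying an amine or a methoxy group in place of the 4-hydroxy or 5-methyl group on the benzimidazole would follow the pair of compound 1 and compound 2 or the pair of compound 3 and compound 4. Also open, on these data alone, is how an amine or a carboxylic acid in place of the hydroxy of the 4-hydroxyphenyl group would read on either core.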